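Swapping Pyrazine for Thiazole on a Bicyclic Amine

A few compounds are considered here, and "the series" means these few. Any claim that something is new, unique, unknown or untested is made for them only; others in the source may bear on it.

Three compounds sharing one saturated core were tested in an ADME assay on MDCK cells (Canis lupus familiaris) for cytotoxicity, read by microscopy, with a stated time of 48 h; on this read-out higher numbers stand for lower toxicity in this test and lower numbers for higher toxicity in this test. Compound 1 `CCc1ccc(CN[C@@H]2C[C@H]3C[C@@H]([C@H]2C)C3(C)C)s1` gives 1560 nM, and compound 3 `CCOc1ccsc1CN[C@@H]1C[C@H]2C[C@@H]([C@H]1C)C2(C)C` gives 50000 nM. Compound 2 `C[C@H]1[C@H](NCc2cnccn2)C[C@H]2C[C@@H]1C2(C)C` reaches only the assay's limit at > 100000 nM, so for it a bound rather than a number is known; it sits at the limit of > 100000 nM in this assay, at which 1 of the 3 values shown sits. Compound 4 `C[C@H]1[C@H](NCc2nccs2)C[C@H]2C[C@@H]1C2(C)C` has not yet been measured; it differs from compound 2 by 1,3-thiazol-2-yl in place of pyrazin-2-yl on a saturated chain carbon bound to an amine nitrogen. For the measured compounds named here, no measured pair shows this exact change, so the size of the step is open. Starting from a limit, the step is expected to run toward a lower, more toxic reading, of moderate size: an at least 1.6-fold lower number from compound 2 to compound 4 (0.22 log units; that floor lies within the scatter). Compound 4 is therefore estimated at 60000 nM, within 10000 nM to 200000 nM.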

Compound 4, minimum cytotoxic concentration: > 100000 nM
Compound 4 gave a limit, no number; the forecaster's own chance of this, stated with the estimate: 40%; at least 1.6-fold (0.22 log units) between middle value and limit.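

Compound 2 and compound 4 each give only a limit in this assay, not a number, so no step can be read between them: the limit of > 100000 nM in this assay, at which 2 of the 4 values shown sit.

From the compounds shown here alone, whether 1,3-thiazol-2-yl in place of pyrazin-2-yl changes the reading at all remains open.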